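This account rests on a few compounds, and the source may have more. Where it says the series, first, only, none or still open, it means among the compounds named here.

Of the compounds shown here, three sharing one core have been measured in an assay on lysate for inhibition of phosphatidylcholine:ceramide cholinephosphotransferase 2 (Homo sapiens), read by HPLC, with stated times of 30 min and 2 h; a lower number here means a stronger inhibitor, a higher number a weaker inhibitor. Compound 3 `O=C(Nc1cccnc1)c1ccccc1OCc1c(Cl)cccc1Cl` gives 690 nM, the lowest of the three numbers. Compound 1 `O=C(Nc1cccnc1)c1ccccc1OCc1ccccc1Cl` stands nearest to it, and in this assay compound 1 gives 1100 nM; the step of a 1.6-fold lower number from compound 1 to compound 3 (0.20 log units; within the scatter) lies within the scatter, so the two cannot be ranked. Compound 2 `N#Cc1cccc(COc2ccccc2C(=O)Nc2cccnc2)c1` is far weaker, and in this assay compound 2 gives 60700 nM.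

Compound 4 `Cc1ccc(F)cc1COc1ccccc1C(=O)Nc1cccnc1` has not yet been measured. It differs from compound 3 in one place: 5-fluoro-2-methylphenyl in place of 2,6-dichlorophenyl on a saturated chain carbon bound to an oxygen on an aromatic ring. Among the measured compounds shown here, two measured steps bear on a swap at this position. The step of a 55-fold higher number from compound 1 to compound 2 (1.74 log units; beyond the scatter) was large, as was the reverse step of an 88-fold lower number from compound 2 to compound 3 (1.94 log units; beyond the scatter). Both show that the group on the saturated chain carbon bound to the oxygen governs the number strongly, and that a 2-chlorophenyl or 2,6-dichlorophenyl is tolerated while a 3-cyanophenyl is not. For the measured compounds named here, the 5-fluoro-2-methylphenyl of compound 4 keeps a substituent at the 2-position, so a collapse like that of compound 2 is not expected, but the fluorine at the 5-position has no measured precedent. Compound 4 is therefore expected to land at 1500 nM, within 500 nM to 5000 nM, an expected step of a 2.2-fold higher number from compound 3 to compound 4 (0.34 log units; beyond the scatter).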

Compound 4, half-maximal inhibitory concentration: 740 nM
Beside the measured number, compound 4's estimate is 2.0-fold (0.31 log units) above it; low and high end bracket the measured number.
By their numbers in this assay, from the lowest: compounds 3, 4 and 1 (each within the scatter of the next); then compound 2.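

In this assay, the swap on the saturated chain carbon bound to an oxygen on an aromatic ring gives a 1.1-fold higher number from compound 3 to compound 4 (0.03 log units; within the scatter), and the other swap among the tolerated groups gives a 1.5-fold lower number from compound 1 to compound 4 (0.17 log units; within the scatter), so the three cannot be ranked. The earlier tolerated groups both carried chlorine, whereas 5-fluoro-2-methylphenyl carries none, which shows that among the compounds shown chlorine is not required for a number in this range. Among the compounds shown here, the step of an 82-fold lower number from compound 2 to compound 4 (1.91 log units; beyond the scatter) matches in size the large steps already seen, leaving the 3-cyanophenyl of compound 2 as the one group that stands apart from 2-chlorophenyl, 2,6-dichlorophenyl and 5-fluoro-2-methylphenyl. Nothing available here explains why these three groups give such similar numbers.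

The compounds shown leave open what the methyl and the fluoro of compound 4 each contribute, since neither a 2-methylphenyl nor a 5-fluorophenyl stands among them. They also leave open whether the nitrile itself or its place on the ring sets compound 2 apart, a question that a 2-cyanophenyl or a 3-chlorophenyl at this position would address.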